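Aryl variation on the shared core: chlorophenyl against hydroxyphenyl

The source may hold more compounds than are shown below. What is called first, only, known or untested is meant among the compounds shown, and "the series" means these compounds.

Compound 1 `Cn1cnc2c(N3CCCCC3)nc(-c3cc(Cl)ccc3Cl)nc21` and compound 2 `Cn1cnc2c(N3CCCCC3)nc(-c3cccc(O)c3)nc21` share one core and differ only in the aryl group. In an assay on cells for displacement of a labelled ligand from adenosine receptor A2b (Homo sapiens), read by scintillation counting and radioligand binding, with a stated time of 30 min, tested at 10 uM (on this read-out higher numbers stand for more inhibition at the one concentration tested (going by the name of the read-out) and lower numbers for less inhibition), compound 1 gives 31%, and compound 2 gives 29.3%, with a number 1.7 percentage points lower from compound 1 to compound 2 (within the scatter). Compound 2 therefore stands at the lower of the two numbers shown, separated from compound 1 only within the scatter. Compound 3 `Cn1cnc2c(N3CCCCC3)nc(-c3ccccc3Cl)nc21` carries the change (2-chlorophenyl in place of 3-hydroxyphenyl on an aromatic carbon). Among the compounds with values here, the one measured step, from compound 1 to compound 2, bears on this swap of aryl groups and stayed within the scatter, so no step beyond the scatter is expected here either, a number 0.7 percentage points higher from compound 2 to compound 3 (within the scatter). Compound 3 is estimated at 30%, in the range 15% to 45%.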

Compound 3, a percentage reported as inhibition, at one concentration (the size of the read-out at that concentration, not a potency): 32.7%
Compound 3: the middle estimate sits 2.7 percentage points below what was measured; the range from low to high includes it.
By their numbers in this assay, from the lowest: compounds 2, 1 and 3 (each within the scatter of the next).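

Within this assay, 2-chlorophenyl in place of 3-hydroxyphenyl removes the hydrogen-bond donor and acceptor of the aryl group and stays within the scatter (a number 3.4 percentage points higher from compound 2 to compound 3 (within the scatter)). Hydrogen in place of one chloro of 2,5-dichlorophenyl also stays within the scatter (a number 1.7 percentage points higher from compound 1 to compound 3 (within the scatter)), so on this aromatic carbon between two ring nitrogen atoms the three aryl groups cannot be told apart on this read-out. Nothing at hand gives a reason for this.

Still open, as far as these compounds go, is whether a non-aryl group here, such as an aliphatic amine, a carboxylic acid or a longer alkyl chain, would give a step beyond the scatter.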